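This account rests on a few compounds, and the source may have more. Where it says the series, first, only, none or still open, it means among the compounds named here.

Working notes on the series. Going by the values given here, in a functional assay (Homo sapiens) for inhibition, with a stated time of 72 h (on this read-out lower numbers stand for stronger inhibition and higher numbers for weaker inhibition), compound 1 (`COc1cc(C(=O)c2ccc3[nH]ccc3c2)cc(OC)c1OC`) gives 111 nM as the lowest of the three numbers so far. Compound 3 (`COc1cc(C(=O)c2cccc3cc[nH]c23)cc(OC)c1OC`) gives 284 nM and compound 2 (`COc1cc(C(=O)c2ccc3cc[nH]c3c2)cc(OC)c1OC`) gives 452 nM, and both lie beyond the scatter from compound 1. Compound 4 (`CCn1ccc2cc(C(=O)c3cc(OC)c(OC)c(OC)c3)ccc21`) carries ethyl in place of hydrogen on an aromatic nitrogen. Among the compounds with values here, no measured pair tests a change at this place, so the expectation is weakly founded. A step in this assay of about the size of the scatter is expected, towards a higher number and weaker inhibition. The estimated step (a 2.0-fold higher number from compound 1 to compound 4 (0.30 log units; within the scatter)) carries wide uncertainty. Compound 4 is estimated at 220 nM (range 60 nM to 800 nM).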

Compound 4, half-maximal inhibitory concentration: 40 nM
Estimate against measurement, compound 4: 5.5-fold (0.74 log units) above; measured number below the stated range.
By their numbers in this assay, from the lowest: compound 4; then compound 1; then compounds 3 and 2 (each within the scatter of the next).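

In this assay, ethyl in place of hydrogen on an aromatic nitrogen gives a 2.8-fold lower number from compound 1 to compound 4 (0.44 log units; beyond the scatter), a modest step beyond the scatter. Compounds 1, 2 and 3 all keep this hydrogen, so only compound 4 shows that inhibition in this assay survives its loss and that this position accepts ethyl. No measurement at hand bears on why the number falls. The compounds shown leave open whether methyl, a longer chain such as propyl or a chain ending in an amine would do the same at this nitrogen. From the compounds shown here alone, whether ethyl would shift compound 2 or compound 3 in the same direction also remains open.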